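Replacing the 2-Chlorophenyl of Compound 2 with (4-Fluorophenyl)amino

The source may hold more compounds than are shown below. What is called first, only, known or untested is meant among the compounds shown, and "the series" means these compounds.

Measured compounds in a functional assay on the whole organism (strain Wistar) for inhibition, with Rattus norvegicus as the target, read by paw edema, with a stated time of 4 h, at a dose of 10 mg/kg by the oral route; on this read-out lower numbers stand for less inhibition and higher numbers for more inhibition at the one dose given (going by the name of the read-out):
compound 1, `Clc1ccc(-c2nnc(COc3ccc(-c4ccccc4)cc3)o2)cc1`, gives 77.3%
compound 2, `Clc1ccccc1-c1nnc(COc2ccc(-c3ccccc3)cc2)o1`, gives 63.6%
compound 3, `COc1ccc2cc(C(C)c3nnc(COc4ccc(-c5ccccc5)cc4)o3)ccc2c1`, gives 25%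

Compound 2 stands second highest of the three numbers in this assay, with compound 1 above it and compound 3 well below it. For the measured compounds named here, the one step measured so far is a number 13.7 percentage points lower from compound 1 to compound 2 (beyond the scatter); compound 3 carries a different group on the same ring carbon and sits lowest. Compound 4, `Fc1ccc(Nc2nnc(COc3ccc(-c4ccccc4)cc3)o2)cc1`, differs from compound 2 as follows: (4-fluorophenyl)amino in place of 2-chlorophenyl on an aromatic carbon. Going by the values given here, no measured step concerns an amino-linked aryl, so the direction is uncertain; the only guide is that a 4-substituted aryl, in compound 1, gave the highest number. Compound 4 is therefore estimated at 62% in this assay, within 38% to 80%, a step of a number 1.6 percentage points lower from compound 2 to compound 4 (within the scatter) expected to stay within the scatter.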

Compound 4, a percentage reported as inhibition, in the whole organism at one dose (the size of the read-out at that dose, not a potency): 52.3%
Estimate against measurement, compound 4: 9.7 percentage points above; measured number inside the range.
By their numbers in this assay, from the lowest: compound 3; then compound 4; then compound 2; then compound 1.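

In this assay the (4-fluorophenyl)amino group brings a number 11.3 percentage points lower from compound 2 to compound 4 (beyond the scatter) and a number 25 percentage points lower from compound 1 to compound 4 (beyond the scatter) against the two chlorophenyl groups. At this aromatic carbon of the shared core, then, an aryl joined through an amino link stands lower than either chlorophenyl joined directly, a pattern resting on these two comparisons alone. Nothing given here accounts for the fall.

The compounds shown leave open whether the amino link or the fluorine goes with the lower number. Neither a directly joined 4-fluorophenyl nor a (4-chlorophenyl)amino group stands among them to separate the two.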